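Replacing a sulfanyl group with a sulfonyl group

This account rests on a few compounds, and the source may have more. Where it says the series, first, only, none or still open, it means among the compounds named here.

Compound 1 `O=C(/C(=C\c1c(O)cc(O)cc1O)S(=O)(=O)c1ccccc1Br)c1ccc(Br)cc1` gives 50000 nM
Compound 2 `Cc1ccc(CS/C(=C/c2c(O)cc(O)cc2O)C(=O)c2ccc(Cl)cc2)cc1` gives 50000 nM

Both values come from a functional assay on DU-145 cells (Homo sapiens) for inhibition, read by trypan blue exclusion, with a stated time of 96 h (on this read-out higher numbers stand for weaker inhibition of growth and lower numbers for stronger inhibition of growth), and stand level, so compound 2 sits with compound 1 within the scatter. Compound 3 `O=C(/C(=C\c1c(O)cc(O)cc1O)S(=O)(=O)c1ccccc1Br)c1ccc(Cl)cc1` differs from compound 2 in having (2-bromophenyl)sulfonyl in place of (4-methylbenzyl)sulfanyl on a double-bonded chain carbon bound to a carbonyl carbon and a double-bonded chain carbon in its structure. For the measured compounds named here, no measured step shows this change. In this assay no step beyond the scatter is expected. The estimated change is no change at the digits printed from compound 2 to compound 3 (within the scatter) in size. For compound 3 the estimated value is 50000 nM with an expected range from 20000 nM to 100000 nM on this read-out.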

Compound 3, concentration for 50% growth inhibition: 50000 nM
Compound 3: the middle estimate sits on the measured number at the digits printed; the measured number falls inside the stated range.
By their numbers in this assay, from the lowest: compounds 1, 2 and 3 (each within the scatter of the next).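

In this assay, (2-bromophenyl)sulfonyl in place of (4-methylbenzyl)sulfanyl on a double-bonded chain carbon bound to a carbonyl carbon and a double-bonded chain carbon gives no change at the digits printed from compound 2 to compound 3 (within the scatter), and chloro in place of bromo on an aromatic carbon gives no change at the digits printed from compound 1 to compound 3 (within the scatter). Each exchange can now be read alone, which the earlier pair, differing in more than one place, did not allow, and neither separates these compounds. Nothing at hand explains this result. As far as these compounds go, whether an amine or a carboxylic acid on that chain carbon would stand apart from these compounds stays open.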